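A few compounds are considered here, and "the series" means these few. Any claim that something is new, unique, unknown or untested is made for them only; others in the source may bear on it.

Compound 1, `NC1=NC2(CCOCC2)N(OCCCOc2cccc(Cl)c2)C(N)=N1`, in an assay on isolated protein for inhibition of Dihydrofolate reductase (Homo sapiens), read by spectrophotometry, using NADPH, with stated times of 5 s and 6 min, tested at 50 uM (a higher number here means a stronger effect of the compound at the concentration tested, a lower number a weaker effect), gives 85.8%.
Compound 2, `NC1=NC2(CCOCC2)N(OCCCOc2ccccc2Br)C(N)=N1`, in this assay gives 85%.
Compound 3, `NC1=NC2(CCOCC2)N(OCCCOc2ccc(Cl)cc2Cl)C(N)=N1`, in this assay gives "not determined" (no result reported).

Compound 3 stands on no number at all: in this assay compound 3 gives "not determined" (no result reported). Compound 4, `Cc1cc(C)cc(OCCCON2C(N)=NC(N)=NC23CCOCC3)c1`, differs from it in one place: 3,5-dimethylphenyl in place of 2,4-dichlorophenyl on an oxygen on a saturated carbon.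

Among the measured compounds shown here, only one measured step exists, and it changes the same group on the same oxygen: a number 0.8 percentage points lower from compound 1 to compound 2 (within the scatter). That step swaps one halogen-bearing phenyl ring for another and leaves the inhibition essentially unchanged, so compounds 1 and 2 show two values that sit together. For the measured compounds named here, no measured pair shows a dimethyl-bearing ring, so the change to compound 4 is not covered directly, and nothing in the data links the nature of the ring substituents to the read-out.

On that basis, compound 4 is expected to land near the values of compounds 1 and 2, with no step beyond the scatter foreseen in either direction. The estimate for compound 4 in this assay is 80%, within 60% to 95%.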

Compound 4, a percentage reported as inhibition, at one concentration (the size of the read-out at that concentration, not a potency): 88.6%
Beside the measured number, compound 4's estimate is 8.6 percentage points below it; the range from low to high includes it.
By their numbers in this assay, from the lowest: compounds 2, 1 and 4 (each within the scatter of the next).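

Until now, only halogen-bearing rings had numbers at this position. Compound 4 shows that 3,5-dimethylphenyl, a ring with no halogen, sits with them in this assay (a number 3.6 percentage points higher from compound 2 to compound 4 (within the scatter); a number 2.8 percentage points higher from compound 1 to compound 4 (within the scatter)). Across these three compounds, then, exchanging chlorine or bromine on the phenyl ring for two methyl groups does not separate the read-out, and no measurement at hand explains why these rings behave alike.

Each number comes from one concentration and sits high, so any difference in potency among these rings stays hidden. Also open, as far as these compounds go, is whether a phenyl ring carrying an amine or a carboxylic acid, or a longer chain in place of the present one, would keep the inhibition at this level.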